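Fluoro on the sulfonyl aryl ring: compound 2 to compound 3

A few compounds are considered here, and "the series" means these few. Any claim that something is new, unique, unknown or untested is made for them only; others in the source may bear on it.

Of the compounds shown here, two carry numbers so far. Compound 1 `CS(=O)(=O)c1ccc(S(=O)(=O)n2cc(CC(=O)O)c3sccc32)cc1` in an assay on HEK293 cells for displacement of a labelled ligand from prostaglandin D2 receptor 2 (Homo sapiens) (a lower number here means a stronger inhibitor, a higher number a weaker inhibitor), gives 5000 nM. Compound 2 `Cc1c(CC(=O)O)c2ccsc2n1S(=O)(=O)c1ccccc1` in this assay gives 2750 nM. Compound 2 thus holds the lower of the two numbers, but its gap to compound 1 lies within the scatter of the assay, so the two cannot be ordered on these data. Among the measured compounds shown here, no pair of measured compounds differs in one place only, so no isolated step is on record.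

Compound 3 `Cc1c(CC(=O)O)c2ccsc2n1S(=O)(=O)c1ccc(F)cc1` has not been measured. It differs from compound 2 by fluoro in place of hydrogen on an aromatic carbon of the six-membered aromatic ring of carbon only, para to a large group; read one bond further out, phenyl becomes 4-fluorophenyl. Nothing in the measured pair speaks to this change. The expected step is small and without clear direction, and is estimated as a 1.3-fold lower number from compound 2 to compound 3 (0.10 log units; within the scatter), within the scatter. Compound 3 is accordingly expected to give 2200 nM in this assay, with a range from 700 nM to 7000 nM.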

Compound 3, half-maximal inhibitory concentration: 1630 nM
Compound 3: middle estimate off by 1.3-fold (0.13 log units), on the high side; measured number inside the range.
By their numbers in this assay, from the lowest: compounds 3, 2 and 1 (each within the scatter of the next, the first and the last beyond it).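

Among the compounds shown here, compounds 2 and 3 supply the first step that isolates a single change: in this assay, fluoro in place of hydrogen on an aromatic carbon, para to a large group, gives a 1.7-fold lower number from compound 2 to compound 3 (0.23 log units; within the scatter) on the sulfonyl aryl ring. Phenyl and 4-fluorophenyl therefore cannot be told apart on these data, and this place accepts a fluoro with no readable shift in the number in either direction, though one small step cannot exclude a real effect hidden within the scatter. No measurement on hand accounts for the size of this step.

Going by these compounds, whether chloro, trifluoromethyl, methoxy or an amine at this same place would move the number beyond the scatter remains open, as a single fluoro says little about the position as a whole. Also open, on these data alone, is how much the number depends on the carboxylic acid and on the methyl on the shared core, since neither has yet been varied alone against compound 2 or compound 3.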